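The source may report more compounds than this note shows. Statements on the series, on what has been measured and on what is new or still open speak of the compounds shown alone.

Three measured compounds share one core: compound 1 `O=C(c1ccc(Cl)cc1)N1CC(c2nc(-c3cccc(F)c3)no2)C1`, compound 2 `O=C(C1CCC(F)(F)CC1)N1CC(c2nc(-c3cccc(F)c3)no2)C1` and compound 3 `O=C(C1CCC(F)(F)CC1)N1CC(c2nc(-c3cccc(Cl)c3)no2)C1`. In an assay on HEK293 cells for positive allosteric modulation of metabotropic glutamate receptor 5 (Homo sapiens), read by FLIPR (a lower number here means that less compound is needed, a higher number that more compound is needed for the effect), compound 1 gives 2500 nM, compound 2 gives 520 nM and compound 3 gives 180 nM. Both measured steps lower the number: a 4.8-fold lower number from compound 1 to compound 2 (0.68 log units; beyond the scatter), and then a 2.9-fold lower number from compound 2 to compound 3 (0.46 log units; beyond the scatter). Compound 3 therefore stands lowest of the three, with compound 2 nearest and compound 1 furthest.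

Compound 4 `COC1CCCN(C(=O)N2CC(c3nc(-c4cccc(Cl)c4)no3)C2)C1` keeps everything of compound 3 except the group on the carbonyl carbon: 3-methoxypiperidin-1-yl in place of 4,4-difluorocyclohexyl on a carbonyl carbon. Among the compounds with values here, only the step from compound 1 to compound 2 touches the same carbon, and it was modest in size, moving from an aromatic group to a saturated carbon ring. Within the data shown here, no measured step replaces a carbon-only ring with a ring holding a nitrogen and a methoxy group, so that part of the change has no precedent. The expected outcome for compound 4 in this assay is a modest rise, a 2.5-fold higher number from compound 3 to compound 4 (0.40 log units; beyond the scatter), which may well stay within the scatter. Compound 4 is thus estimated at 450 nM, in a range from 120 nM to 1700 nM.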

Compound 4, half-maximal effective concentration: > 10000 nM
Compound 4 ended at the assay's limit; the forecaster's own chance of this, stated with the estimate: 5%; middle value at least 22-fold (1.34 log units) from the limit.
By their numbers in this assay, from the lowest: compound 3; then compound 2; then compound 1. At a limit, above all of these: compound 4.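

In this assay, 3-methoxypiperidin-1-yl in place of 4,4-difluorocyclohexyl on a carbonyl carbon gives an at least 55-fold higher number from compound 3 to compound 4 (1.74 log units; beyond the scatter). Within the data shown here, the group on this carbon can therefore raise the number sharply as well as lower it, whereas the only earlier step here, a 4.8-fold lower number from compound 1 to compound 2 (0.68 log units; beyond the scatter), went downward; two six-membered non-aromatic rings of equal heavy-atom count are far from interchangeable at this position. Compound 4 gives > 10000 nM, which is a limit and not a number: the limit of > 10000 nM in this assay, at which 1 of the 4 values shown sits.

The ring nitrogen and the methoxy group enter together, so the compounds shown do not tell which of the two goes with the loss; plain piperidin-1-yl or 3-methoxycyclohexyl on the same carbon would separate them. From the compounds shown here alone, how far compound 4 lies past the limit also stays open.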